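The source may hold more compounds than are shown below. What is called first, only, known or untested is meant among the compounds shown, and "the series" means these compounds.

Measured compounds:
- compound 1, `CCn1cc(-c2nc3ccccc3s2)c(=O)c2cc(F)c(N3CCNCC3)cc21`: 11300 nM
- compound 2, `CCn1cc(-c2nc3ccccc3s2)c(=O)c2cc(F)c(N3CCNCC3)nc21`: 2700 nM
- compound 3, `CCn1cc(-c2nc3ccc(Cl)cc3[nH]2)c(=O)c2cc(F)c(N3CCNCC3)nc21`: 6300 nM

All three were tested in a functional assay on A2780 cells (Homo sapiens) for cytotoxicity, read by MTT assay, with a stated time of 48 h; on this read-out higher numbers stand for weaker inhibition and lower numbers for stronger inhibition. Compound 1 gives the highest of the three numbers there, 11300 nM. Compound 2 gives 2700 nM, and compound 3 gives 6300 nM. The values of compound 1 and compound 3 lie within the usual scatter of each other, so no order between them can be claimed; the gap between compound 1 and compound 2 lies beyond it.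

Compound 2 and compound 3 differ in one place: 6-chloro-1H-benzimidazol-2-yl in place of 1,3-benzothiazol-2-yl on an aromatic carbon. That change brought a 2.3-fold higher number from compound 2 to compound 3 (0.37 log units; beyond the scatter). Compound 1 and compound 2 have different cores; the difference between the two cores is not broken down here.

The unmeasured compound 4, `CCn1cc(-c2nc3ccc(Cl)cc3[nH]2)c(=O)c2cc(F)c(N3CCNCC3)cc21`, is built from compound 1 by the same change: 6-chloro-1H-benzimidazol-2-yl in place of 1,3-benzothiazol-2-yl on an aromatic carbon. The place is described in the same words for both pairs, so the change is the same, only on the core of compound 1 instead of the core of compound 2.

Among the compounds with values here, because the one earlier example of this change gave a 2.3-fold higher number from compound 2 to compound 3 (0.37 log units; beyond the scatter), a similar step is expected on the core of compound 1, so that compound 4 is estimated to show a 2.3-fold higher number from compound 1 to compound 4 (0.36 log units; beyond the scatter). This rests on a single pair, so the expectation is loose. For compound 4 the estimated value in this assay is 26000 nM, expected to fall between 12000 nM and 55000 nM.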

Compound 4, half-maximal inhibitory concentration: 4900 nM
The estimate for compound 4 lay 5.3-fold (0.72 log units) above the measured number; measured number outside the range, below it.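

On the core of compound 1, putting 6-chloro-1H-benzimidazol-2-yl in place of 1,3-benzothiazol-2-yl gave in this assay a 2.3-fold lower number from compound 1 to compound 4 (0.36 log units; beyond the scatter), so the number moved the opposite way from the earlier example of this change. Set side by side, the two steps do not agree: the same change on two cores in this assay, a 2.3-fold higher number (0.37 log units; beyond the scatter) from compound 2 to compound 3 and a 2.3-fold lower number (0.36 log units; beyond the scatter) from compound 1 to compound 4, 5.4-fold (0.73 log units) apart, beyond the scatter of two such steps. Within these four compounds, then, the outcome of this change depends on the core it is made on, and a step measured on one core cannot simply be carried over to the other; what this does not show is why the two cores differ, and with only one pair on each core it says nothing about other cores or other replacements.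

The compounds shown leave open how a 1H-benzimidazol-2-yl group without the chlorine would behave on either core, so the share of the chlorine and the share of the exchange of one fused ring system for the other in each step cannot be told apart. They also leave open whether a quite different group at the same place, such as a carboxylic acid, would show the same dependence on the core.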